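Cytotoxicity of a benzyl ether flavonol series: predicting the 3-methyl analogue

The compounds below may be only part of what the source reports. "The series", "measured", "known", "first", "only" and "open" are said of these compounds alone.

Measured compounds:
compound 1 `N#Cc1ccccc1COc1cc(O)c2c(=O)c(O)c(-c3ccccc3)oc2c1` 22000 nM
compound 2 `Cc1ccccc1COc1cc(O)c2c(=O)c(O)c(-c3ccccc3)oc2c1` 17000 nM
compound 3 `O=c1c(O)c(-c2ccccc2)oc2cc(OCc3cccc([N+](=O)[O-])c3)cc(O)c12` 76000 nM

Three compounds sharing one core were tested in an ADME assay on Huh-5-2 cells (Homo sapiens) for cytotoxicity, read by WST assay, with a stated time of 3 days; a lower number here means that less compound is tolerated, a higher number that more compound is tolerated. Compound 1 stands second highest of the three numbers; its nearest neighbour is compound 2, which gives 17000 nM, a difference that stays within the scatter (a 1.3-fold lower number from compound 1 to compound 2 (0.11 log units; within the scatter)). Compound 3 lies furthest away and gives 76000 nM, a modest step beyond the scatter (a 3.5-fold higher number from compound 1 to compound 3 (0.54 log units; beyond the scatter)), echoed by a 4.5-fold higher number from compound 2 to compound 3 (0.65 log units; beyond the scatter).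

Compound 4 `Cc1cccc(COc2cc(O)c3c(=O)c(O)c(-c4ccccc4)oc3c2)c1` has not yet been measured. It differs from compound 1 in this way: 3-methylphenyl in place of 2-cyanophenyl on a saturated chain carbon bound to an oxygen on an aromatic ring. Among the measured compounds shown here, two measured steps bear on it. The exchange of cyano for methyl on the aromatic carbon, in a 1.3-fold lower number from compound 1 to compound 2 (0.11 log units; within the scatter), changed nothing beyond the scatter. Moving a substituted phenyl to the 3-substituted form, in a 3.5-fold higher number from compound 1 to compound 3 (0.54 log units; beyond the scatter), gave a modest higher number, though with a nitro group rather than a methyl. Taken together, a small upward step, or none beyond the scatter, is expected in this assay.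

Compound 4 is therefore expected to give about 28000 nM, within 12000 nM to 65000 nM, an estimated step of a 1.3-fold higher number from compound 1 to compound 4 (0.10 log units; within the scatter).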

Compound 4, half-maximal cytotoxic concentration: 35000 nM
For compound 4 the middle estimate is 1.3-fold (0.10 log units) below the measured one; the measured number falls inside the stated range.
By their numbers in this assay, from the lowest: compounds 2, 1 and 4 (each within the scatter of the next, the first and the last beyond it); then compound 3.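

With the methyl group held constant, the 3-methylphenyl in place of 2-methylphenyl gives a step beyond the scatter in this assay (a 2.1-fold higher number from compound 2 to compound 4 (0.31 log units; beyond the scatter)), so the place of the substituent on this phenyl ring can alter the number without any change in the group itself. The place alone does not account for compound 3, since methyl in place of nitro on the same aromatic carbon also gives a step beyond the scatter (a 2.2-fold lower number from compound 3 to compound 4 (0.34 log units; beyond the scatter)). Exchanging 2-cyanophenyl for 3-methylphenyl, which alters both group and place, stays within the scatter (a 1.6-fold higher number from compound 1 to compound 4 (0.20 log units; within the scatter)). Nothing available here accounts for these steps.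

The compounds shown leave open how 3-cyanophenyl or 2-nitrophenyl would compare with their counterparts here. They also leave open how a phenyl bearing an amine or a carboxylic acid would stand.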